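The compounds below may be only part of what the source reports. "The series", "measured", "known", "first", "only" and "open" are said of these compounds alone.

Series in a functional assay on T98G cells (Homo sapiens) for cytotoxicity, read by MTT assay, with a stated time of 48 h; on this read-out lower numbers stand for stronger inhibition and higher numbers for weaker inhibition:
compound 1 `C/C(=N\NC(=S)Nc1ccc(Cl)cc1)c1ccccn1` - 5.9 nM
compound 2 `C/C(=N/NC(=S)Nc1ccccc1)c1ccccn1` - 6.81 nM
compound 3 `C/C(=N/NC(=S)Nc1ccc(Cl)cc1)c1ccccn1` - not yet measured

Compound 2 at 6.81 nM lies within the scatter of compound 1 at 5.9 nM, so the two cannot be told apart on these numbers. Compound 3 departs from compound 2 by chloro in place of hydrogen on an aromatic carbon, with chloro in place of hydrogen on an aromatic carbon, para to a large group. Within the data shown here, no measured step covers this change, so no shift beyond the scatter is expected in this assay. The estimated change, a 1.1-fold lower number from compound 2 to compound 3 (0.05 log units; within the scatter), is small. For compound 3 the expected value is 6 nM, with an estimated range of 2.5 nM to 14 nM.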

Compound 3, half-maximal inhibitory concentration: 5.9 nM
Compound 3: middle estimate off by 1.0-fold (0.01 log units), on the high side; the range from low to high includes it.
By their numbers in this assay, from the lowest: compounds 1, 3 and 2 (each within the scatter of the next).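

Chloro in place of hydrogen on an aromatic carbon, para to a large group, gives a 1.2-fold lower number from compound 2 to compound 3 (0.06 log units; within the scatter) in this assay and so does not separate the two compounds. The drawn configuration of the double bond can now be read as well: it gives no change at the digits printed from compound 1 to compound 3 (within the scatter) and rests on a single pair: the fact that compounds 1 and 3 differ only in the configuration as drawn.

Open remain other groups at this place, such as an amine or a carboxylic acid. Also open, as far as these compounds go, is whether the drawn configuration reads the same with hydrogen in place of chloro.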